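Replacing an Ether Link with an Amine Link

A few compounds are considered here, and "the series" means these few. Any claim that something is new, unique, unknown or untested is made for them only; others in the source may bear on it.

Compound 1, `Nc1cc(N)c2nc(-c3ccccc3)c(Oc3ccc(F)cc3)nc2c1`: 13800 nM
Compound 2, `COc1cc(CNc2nc3cc(N)cc(N)c3nc2-c2ccccc2)cc(OC)c1OC`: 5370 nM
Compound 3, `CCOC(=O)[C@H](CCC(=O)O)NC(=O)c1ccc(Oc2nc3cc(N)cc(N)c3nc2-c2ccccc2)cc1`: 5370 nM

These three compounds share one core and were tested in a functional assay on ACHN cells (Homo sapiens) for inhibition, read by sulforhodamine B assay, with a stated time of 48 h; on this read-out higher numbers stand for weaker inhibition of growth and lower numbers for stronger inhibition of growth. Compound 1 gives 13800 nM, the highest of the three numbers. Compound 2 gives 5370 nM and compound 3 gives 5370 nM; each of these lies beyond the scatter below compound 1, while compounds 2 and 3 sit within the scatter of each other, so no order between them can be claimed.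

Not yet measured is compound 4, `Nc1cc(N)c2nc(-c3ccccc3)c(NCc3ccc(F)cc3)nc2c1`. Set against compound 1, the change is: (4-fluorobenzyl)amino in place of 4-fluorophenoxy on an aromatic carbon. For the measured compounds named here, no measured pair differing in only one place is available, so the size of this step cannot be read off directly; a modest step toward stronger inhibition of growth, or none beyond the scatter, is expected. The expectation leans toward improvement because compound 2 gives 5370 nM while carrying its side arm through an amino group. Compound 4 is therefore estimated at 6500 nM, with a range from 2500 nM to 16000 nM. This estimate means an expected step of a 2.1-fold lower number from compound 1 to compound 4 (0.33 log units; beyond the scatter).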

Compound 4, concentration for 50% growth inhibition: 1700 nM
For compound 4 the middle estimate is 3.8-fold (0.58 log units) above the measured one; the whole stated range lies above it.
By their numbers in this assay, from the lowest: compound 4; then compounds 2 and 3 (each within the scatter of the next); then compound 1.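

In this assay, for the compounds shown here, putting (4-fluorobenzyl)amino in place of 4-fluorophenoxy gives an 8.1-fold lower number from compound 1 to compound 4 (0.91 log units; beyond the scatter), the first step here that can be read from a single change. It shows that this aromatic carbon, next to the ring nitrogen, responds to the make-up of its side arm, with stronger inhibition of growth for the new group. The entering group differs in two ways at once, carrying a hydrogen-bond donor that the leaving group lacks and a longer link to its ring, and no measurement on hand explains the step.

The compounds shown leave open which of these two differences carries the step, and a (4-fluorophenyl)amino or a 4-fluorobenzyloxy group at this carbon would separate them. Also open, going by these compounds, is what the fluorine contributes, which a plain benzylamino group would test.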